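The source may report more compounds than this note shows. Statements on the series, on what has been measured and on what is new or still open speak of the compounds shown alone.

Measured so far:
- Compound 1, `O=C1O[C@H]([C@@H](O)Cn2cc(-c3cc(F)cc(F)c3)nn2)C(OCc2ccccc2)=C1OCc1ccccc1`: 48200 nM
- Compound 2, `O=C1O/C(=C\Cn2cc(-c3cccc(O)c3)nn2)C(OCc2ccccc2)=C1OCc1ccccc1`: 63600 nM
- Compound 3, `CCCCCc1ccc(-c2cn(C/C=C3\OC(=O)C(OCc4ccccc4)=C3OCc3ccccc3)nn2)cc1`: only a limit of the assay, > 100000 nM

All three were tested in a functional assay on HCT-116 cells (Homo sapiens) for antiproliferative activity, read by MTT assay, with a stated time of 72 h; a higher number here means a weaker inhibitor, a lower number a stronger inhibitor. Compound 1 gives the lowest of the two plain numbers, but its gap to compound 2 lies within the scatter. Compound 4, `CCCCc1cn(C[C@H](O)[C@H]2OC(=O)C(OCc3ccccc3)=C2OCc2ccccc2)nn1`, differs from compound 1 by butyl in place of 3,5-difluorophenyl on an aromatic carbon. Among the compounds with values here, the only measured step at that same place of the core is an at least 1.5-fold higher number from compound 2 to compound 3 (0.19 log units; that floor lies within the scatter), which at its floor lies within the scatter and reaches only a limit (the limit of > 100000 nM in this assay, at which 1 of the 3 values shown sits). No shown step speaks to exchanging an aromatic ring for a chain there. Compound 4 is therefore expected to stay close to compound 1, with a 1.0-fold higher number from compound 1 to compound 4 (0.02 log units; within the scatter) not beyond the scatter, estimated at 50000 nM within 20000 nM to 100000 nM.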

Compound 4, half-maximal inhibitory concentration: 10400 nM
Compound 4: middle estimate off by 4.8-fold (0.68 log units), on the high side, outside the stated range (below it).
By their numbers in this assay, from the lowest: compound 4; then compounds 1 and 2 (each within the scatter of the next). At a limit, above all of these: compound 3.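

Within the data shown here, the a 4.6-fold lower number from compound 1 to compound 4 (0.67 log units; beyond the scatter) is the first step at this aromatic carbon to lie beyond the scatter. It shows that an aromatic ring is not needed there for activity on these cells, since butyl, which has no ring, gives the lower number in place of 3,5-difluorophenyl. From the compounds shown here alone, the earlier step at this place ends with compound 3 at a limit, so its full size stays unknown: the limit of > 100000 nM in this assay, at which 1 of the 4 values shown sits.

Still open, going by these compounds, is whether a longer chain, an amine or a carboxylic acid at this carbon would lower the number further. Also open, on these data alone, is whether butyl would have the same effect on the core of compound 2.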